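Lengthening the Alkyl Chain in a Kallikrein-7 Inhibitor Series

This account rests on a few compounds, and the source may have more. Where it says the series, first, only, none or still open, it means among the compounds named here.

Compound 1 `CCCCCCCCCCC/C(O)=C1/C(=O)[C@H](Cc2ccccc2)N(C(=O)OC(C)(C)C)C1=O` was tested in an assay on isolated protein for inhibition of kallikrein-7 (Homo sapiens) (on this read-out higher numbers stand for weaker inhibition and lower numbers for stronger inhibition), where compound 1 gives 2300 nM. Within the data shown here, of the two numbers measured so far, this is the highest; the nearest is compound 2 `CCCCCCCCCCCCC/C(O)=C1/C(=O)[C@H](Cc2ccccc2)N(C(=O)OC(C)(C)C)C1=O`, which in this assay gives 1700 nM. Among the measured compounds shown here, the only measured step, a 1.4-fold lower number from compound 1 to compound 2 (0.13 log units; within the scatter), consists of ethyl in place of hydrogen on a saturated chain carbon, ten or more bonds along the chain from a double-bonded chain carbon, and it stays within the scatter.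

Compound 3 `CCCCCCCCCCCCCCC/C(O)=C1/C(=O)[C@H](Cc2ccccc2)N(C(=O)OC(C)(C)C)C1=O` has not yet been measured. It differs from compound 1 by butyl in place of hydrogen on a saturated chain carbon, ten or more bonds along the chain from a double-bonded chain carbon, the same kind of chain extension as in the measured step, only longer. That measured step bears directly on it, but it was small enough to count as noise, so there is no basis for expecting a clear shift in this assay for compound 3. A somewhat lower number is possible, yet a change beyond the scatter is not expected. Compound 3 is therefore estimated at 1400 nM, with a range of 500 nM to 3500 nM, which corresponds to an expected step of a 1.6-fold lower number from compound 1 to compound 3 (0.22 log units; within the scatter).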

Compound 3, half-maximal inhibitory concentration: 2900 nM
Compound 3: the middle estimate sits 2.1-fold (0.32 log units) below what was measured, within the range that was stated.
By their numbers in this assay, from the lowest: compounds 2, 1 and 3 (each within the scatter of the next).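

In this assay, the butyl added to the chain of compound 1 gives (a 1.3-fold higher number from compound 1 to compound 3 (0.10 log units; within the scatter)), and the further ethyl on the chain of compound 2 gives (a 1.7-fold higher number from compound 2 to compound 3 (0.23 log units; within the scatter)). Among these compounds, with a third chain length in hand, the single earlier step can now be read as part of a wider picture: all three compounds lie within the usual scatter of repeat measurements, so across compounds 1, 2 and 3 the chain length shows no trend in either direction, and this part of the chain tolerates extension without a clear effect on the read-out. Nothing among the available data offers an explanation for this flat picture.

The compounds shown all carry long unbranched chains, so it remains open whether a much shorter chain, such as methyl or propyl, would give a clearly different number. As far as these compounds go, it also remains open whether a chain carrying an amine or a carboxylic acid would move the number beyond the scatter, which the hydrocarbon chains here do not do.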